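The source may hold more compounds than are shown below. What is called first, only, known or untested is meant among the compounds shown, and "the series" means these compounds.

Working notes on the series. In an ADME assay on WI-38 cells (Homo sapiens) for cytotoxicity, read by MTT assay, with a stated time of 72 h (on this read-out lower numbers stand for stronger inhibition and higher numbers for weaker inhibition), compound 1 `CN(C)CCn1cnnc1-c1cc(Oc2ccc(NC(=O)N/N=C/c3ccccc3)cc2F)ccn1` is recorded as "not determined" (no result reported). Among the measured compounds shown here, compound 2 `CN(C)CCn1cnnc1-c1cc(Oc2ccc(NC(=O)N/N=C/c3ccc(F)cc3F)cc2F)ccn1` gives 5030 nM in this assay, the only number so far, so it stands alone with nothing to compare against. Compound 3 `CN(C)CCn1cnnc1-c1cc(Oc2ccc(NC(=O)N/N=C/c3ccc(F)cc3Cl)cc2F)ccn1` differs from compound 2 in one place, (chloro in place of fluoro on an aromatic carbon), which cut one bond further out reads 2,4-difluorophenyl to 2-chloro-4-fluorophenyl. For the measured compounds named here, no step between measured compounds exists to lean on. The expected step is a 1.3-fold lower number from compound 2 to compound 3 (0.10 log units; within the scatter), which is none beyond the usual scatter. Compound 3 is therefore estimated at 4000 nM, with a range from 1500 nM to 10000 nM.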

Compound 3, half-maximal inhibitory concentration: 2090 nM
The estimate for compound 3 lay 1.9-fold (0.28 log units) above the measured number; the measured number falls inside the stated range.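

In this assay, chloro in place of fluoro on an aromatic carbon, ortho to a large group, gives a 2.4-fold lower number from compound 2 to compound 3 (0.38 log units; beyond the scatter), so the identity of the halogen at this position can move the number beyond the scatter. This rests on one pair, 2,4-difluorophenyl to 2-chloro-4-fluorophenyl, and the step is modest. No measurement at hand accounts for the step. Open, going by these compounds, is whether bromo, methyl or methoxy at this position would extend the step or reverse it. Also open, on these data alone, is whether the same change would hold with an amine in place of the dimethylaminoethyl chain.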